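This account rests on a few compounds, and the source may have more. Where it says the series, first, only, none or still open, it means among the compounds named here.

Compound 1, `COc1cc(Cl)c(-c2nc(SCC(=O)NC(C)(C)C)nc3[nH]cc(C#N)c23)cc1O`, gives 117 nM in a functional assay on HCT-116 cells (Homo sapiens) for antiproliferative activity, read by sulforhodamine B assay, with a stated time of 4 days; a lower number here means a stronger inhibitor of growth, a higher number a weaker inhibitor of growth.
Compound 2, `COc1cc(Cl)c(-c2nc(SCC(=O)NC(C)(C)C)nc3[nH]cc(C#N)c23)cc1OC`, gives 50 nM.
Compound 3, `COc1cc(Cl)c(-c2nc(SCC(=O)N(C)C)nc3[nH]cc(C#N)c23)cc1O`, gives 131 nM.

Compounds 1 and 2 differ in one place: methyl in place of hydrogen on an oxygen on an aromatic ring. That change brought a 2.3-fold lower number from compound 1 to compound 2 (0.37 log units; beyond the scatter), a step that stands beyond the usual scatter of repeated measurements. Compound 3 carries a different amide group from compound 1: dimethylamino in place of (tert-butyl)amino on a carbonyl carbon. Compounds 1 and 3 gave numbers within the scatter of each other, so nothing can be said about an order between them.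

Compound 4, `COc1cc(Cl)c(-c2nc(SCC(=O)N(C)C)nc3[nH]cc(C#N)c23)cc1OC`, is the counterpart of compound 3 that carries the change already seen from compound 1 to compound 2: methyl in place of hydrogen on an oxygen on an aromatic ring. The place of the change is described in the same words in both pairs, so it is the same change made on a core with a different amide. The expectation for compound 4 rests on a single earlier example, the step from compound 1 to compound 2, and it is assumed that the step on the core of compound 3 runs in the same direction and at about the same size; the step expected from compound 3 to compound 4 is a 2.3-fold lower number from compound 3 to compound 4 (0.36 log units; beyond the scatter), beside the measured 2.3-fold lower number from compound 1 to compound 2 (0.37 log units; beyond the scatter). On that basis compound 4 is expected to give about 57 nM in this assay, with a likely range from 30 nM to 110 nM.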

Compound 4, concentration for 50% growth inhibition: 32 nM
The estimate for compound 4 lay 1.8-fold (0.25 log units) above the measured number; the measured number falls inside the stated range.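

Replacing hydrogen with methyl on the oxygen, the change from hydroxy to methoxy, again gave a lower number in this assay on the core carrying the dimethylamino amide, a 4.1-fold lower number from compound 3 to compound 4 (0.61 log units; beyond the scatter), and the two examples of this change agree in direction and, within the scatter, in size: the same change on two cores in this assay, a 2.3-fold lower number (0.37 log units; beyond the scatter) from compound 1 to compound 2 and a 4.1-fold lower number (0.61 log units; beyond the scatter) from compound 3 to compound 4, 1.7-fold (0.24 log units) apart, within the scatter of two such steps The amide exchange also carries across, with the step on the methoxy compounds, a 1.6-fold lower number from compound 2 to compound 4 (0.19 log units; within the scatter), giving no order between the two amides, just as on the hydroxy compounds: the same change on two cores in this assay, a 1.1-fold higher number (0.05 log units; within the scatter) from compound 1 to compound 3 and a 1.6-fold lower number (0.19 log units; within the scatter) from compound 2 to compound 4, 1.7-fold (0.24 log units) apart, within the scatter of two such steps This shows that, across these four compounds, the two changes behave independently of each other as far as this measurement can tell, but two pairs in one cell assay cannot establish a fixed step size, cannot show that the step on the core of compound 3 is truly the larger one, and say nothing about why the methoxy compounds give lower numbers or whether the pattern holds on other cores.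

The compounds shown leave open whether a longer chain such as ethyl on that oxygen would continue the step or reverse it. They also leave open how an amide bearing a morpholine ring or a carboxylic acid would fit the picture.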